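From Isopropoxy to Isobutoxy: Expected Binding of Compound 3

The compounds below may be only part of what the source reports. "The series", "measured", "known", "first", "only" and "open" are said of these compounds alone.

Measured in an assay on isolated protein for binding affinity to interleukin-15 (Homo sapiens), read by surface plasmon resonance; a higher number here means weaker binding, a lower number tighter binding:
Compound 1, `COc1ccc(NC(=O)CCCCCCCSc2nnc(Cc3nn(C)c(=O)c4ccccc34)n2C)cc1`: 26000 nM
Compound 2, `CC(C)Oc1ccc(NC(=O)CCCCCCCSc2nnc(Cc3nn(C)c(=O)c4ccccc34)n2C)cc1`: 20900 nM

Only these two compounds have been measured, and they differ solely in the group on the oxygen on the aromatic ring. For the measured compounds named here, compound 2 gives 20900 nM in this assay, and its one neighbour, compound 1, lies within the usual scatter of it, as the step of a 1.2-fold lower number from compound 1 to compound 2 (0.09 log units; within the scatter) shows; neither compound can be called the tighter binder.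

Compound 3, `CC(C)COc1ccc(NC(=O)CCCCCCCSc2nnc(Cc3nn(C)c(=O)c4ccccc34)n2C)cc1`, carries the same shared core and differs from compound 2 by isobutyl in place of isopropyl on an oxygen on an aromatic ring. Going by the values given here, the only measured step that bears on this change is a 1.2-fold lower number from compound 1 to compound 2 (0.09 log units; within the scatter), which lengthened the same group and produced nothing beyond the scatter. On that basis the expected step in this assay from compound 2 to compound 3 is a 1.2-fold lower number from compound 2 to compound 3 (0.06 log units; within the scatter), meaning no change beyond the scatter. Compound 3 is therefore estimated at 18000 nM, with a range from 7000 nM to 45000 nM.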

Compound 3, dissociation constant: 25000 nM
The estimate for compound 3 lay 1.4-fold (0.14 log units) below the measured number; the measured number falls inside the stated range.
By their numbers in this assay, from the lowest: compounds 2, 3 and 1 (each within the scatter of the next).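

In this assay, isobutyl on this oxygen cannot be told apart from isopropyl, with a 1.2-fold higher number from compound 2 to compound 3 (0.08 log units; within the scatter), so the added carbon makes no readable difference here. Isobutyl also cannot be told apart from the much smaller methyl, with a 1.0-fold lower number from compound 1 to compound 3 (0.02 log units; within the scatter), which means that all three compounds shown, carrying methyl, isopropyl and isobutyl on the oxygen on the aromatic ring, sit within the scatter of one another. No measurement at hand offers a reason for this sameness.

The compounds shown leave open whether a group of another kind on this oxygen, such as a benzyl group, a chain ending in an amine or one ending in a carboxylic acid, would move the number beyond the scatter. They also leave open what a hydroxyl group would do in place of the whole alkoxy group.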